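Series notes: from compound 2 to compound 3

The source may hold more compounds than are shown below. What is called first, only, known or untested is meant among the compounds shown, and "the series" means these compounds.

Measured in a functional assay on CHO cells for agonist activity at metabotropic glutamate receptor 2 (Homo sapiens), read by GTPgammaS binding; on this read-out higher numbers stand for larger maximal responses and lower numbers for smaller maximal responses:
compound 1 `CCCn1ccc2cc(N3CCNCC3)cc(Cl)c2c1=O` gives 47%
compound 2 `CCCn1ccc2cc(OCc3cccnc3)cc(Cl)c2c1=O` gives 126%

Compound 2 stands highest of the two numbers recorded in this assay; its nearest neighbour is compound 1, whose largest response is lower by an amount beyond the usual scatter. For the measured compounds named here, no pair among the measured compounds differs in a single place, so no measured step is available to lean on.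

Compound 3 `CCCn1ccc2cc(OCCc3cccnc3)cc(Cl)c2c1=O` is the next candidate. It differs from compound 2 by (pyridin-3-yl)methyl in place of pyridin-3-yl on a saturated chain carbon bound to an oxygen on an aromatic ring.

Going by the values given here, with no comparable step recorded, the change is treated as a modest one for the largest response, and the step from compound 2 to compound 3 in this assay is expected to be a number 16 percentage points lower from compound 2 to compound 3 (beyond the scatter), that is, no clear direction beyond the scatter. Compound 3 is therefore estimated to reach 110%, with a likely range from 60% to 140%.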

Compound 3, largest response reached (Emax), in percent of the reference or control that the assay uses: 47%
Estimate against measurement, compound 3: 63 percentage points above; measured number below the stated range.
By their numbers in this assay, from the lowest: compounds 1 and 3 (each within the scatter of the next); then compound 2.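

At this position, on a saturated chain carbon bound to an oxygen on an aromatic ring, the largest response in this assay proves highly sensitive to the length of the chain carrying the pyridine: going from (pyridin-3-yl)methyl to 2-(pyridin-3-yl)ethyl gives a number 79 percentage points lower from compound 2 to compound 3 (beyond the scatter), a large step. The pyridin-3-yl ring itself is retained in both compounds, so this pair shows that keeping the ring does not on its own preserve the response of compound 2. No supporting measurement bears on why the response changes with this extension.

As far as these compounds go, whether a longer chain such as 3-(pyridin-3-yl)propyl would lower the response further or restore it remains open. Also open, from the compounds shown here alone, is whether a phenyl ring in place of the pyridine would respond to the same extension in the same way.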